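A Vinyl for Phenoxy Swap on the Ethoxy Analogue

This account rests on a few compounds, and the source may have more. Where it says the series, first, only, none or still open, it means among the compounds named here.

Compound 1 `COc1ccc(C2C(Oc3ccccc3)C(=O)N2c2cc(OC)c(OC)c(OC)c2)cc1` carries a phenoxy group on the shared core together with a 4-methoxyphenyl group. In a functional assay on MCF7 cells (Homo sapiens) for inhibition, read by resazurin assay, with a stated time of 72 h (on this read-out higher numbers stand for weaker inhibition and lower numbers for stronger inhibition), compound 1 gives 23 nM. Compound 2 `C=CC1C(=O)N(c2cc(OC)c(OC)c(OC)c2)C1c1ccc(OC)cc1` differs from compound 1 by vinyl in place of phenoxy on a saturated ring carbon; in this assay compound 2 gives 17 nM, so that a 1.4-fold lower number from compound 1 to compound 2 (0.13 log units; within the scatter). Compound 3 `CCOc1ccc(C2C(Oc3ccccc3)C(=O)N2c2cc(OC)c(OC)c(OC)c2)cc1` differs from compound 1 by methyl in place of hydrogen on a saturated chain carbon bound to an oxygen on an aromatic ring. In this assay compound 3 gives 69 nM, and a 3.0-fold higher number from compound 1 to compound 3 (0.48 log units; beyond the scatter), which leaves compound 3 with the highest number of the three measured compounds.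

Compound 4 `C=CC1C(=O)N(c2cc(OC)c(OC)c(OC)c2)C1c1ccc(OCC)cc1` has not yet been measured. It differs from compound 3 by vinyl in place of phenoxy on a saturated ring carbon. This is the same kind of change as that from compound 1 to compound 2, but here the saturated ring carbon sits next to the ring atom that bears a 4-ethoxyphenyl group rather than a 4-methoxyphenyl group. Because the earlier step of a 1.4-fold lower number from compound 1 to compound 2 (0.13 log units; within the scatter) stayed within the scatter, a step of similar size is expected for compound 4, namely a 1.4-fold lower number from compound 3 to compound 4 (0.14 log units; within the scatter). Compound 4 is therefore estimated to give about 50 nM, with a range from 20 nM to 120 nM.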

Compound 4, half-maximal inhibitory concentration: 14 nM
Estimate against measurement, compound 4: 3.6-fold (0.55 log units) above; measured number outside the range, below it.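

On the core bearing the 4-ethoxyphenyl group, vinyl in place of phenoxy gives a 4.9-fold lower number from compound 3 to compound 4 (0.69 log units; beyond the scatter) in this assay, so this change does not carry over at the same size from one core to the other: the same change on two cores in this assay, a 1.4-fold lower number (0.13 log units; within the scatter) from compound 1 to compound 2 and a 4.9-fold lower number (0.69 log units; beyond the scatter) from compound 3 to compound 4, 3.6-fold (0.56 log units) apart, beyond the scatter of two such steps. Read the other way round, among the two vinyl compounds methyl in place of hydrogen on the chain carbon bound to the oxygen gives a 1.2-fold lower number from compound 2 to compound 4 (0.08 log units; within the scatter), so that change does not carry over at the same size either: the same change on two cores in this assay, a 3.0-fold higher number (0.48 log units; beyond the scatter) from compound 1 to compound 3 and a 1.2-fold lower number (0.08 log units; within the scatter) from compound 2 to compound 4, 3.6-fold (0.56 log units) apart, beyond the scatter of two such steps. These four compounds form a single closed square, so the two comparisons report one gap seen from two sides, and they show neither why the steps differ nor whether either step would hold on any further core.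

The compounds shown leave open how an amine or a longer chain in place of vinyl on the saturated ring carbon would behave on these two cores. They also leave open whether a propoxy group in place of the ethoxy group would follow compound 3 or compound 4.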